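A few compounds are considered here, and "the series" means these few. Any claim that something is new, unique, unknown or untested is made for them only; others in the source may bear on it.

Of the compounds shown here, three sharing one core have been tested so far in an ADME assay on microsomes from liver (Mus musculus) for metabolic stability, read by LC-MS, with NADPH named in the record, with a stated time of 60 min, tested at 1 uM, in the absence of a further agent; on this read-out lower numbers stand for a less stable compound and higher numbers for a more stable compound. Compound 1 `COc1ccc(-c2c(C)nc3c(N4CC[C@@H](NC(=O)c5ccccc5)C4)cc(C)nn23)cc1OC` gives > 95%, which is a limit of the assay and not a number. Compound 2 `COc1ccc(-c2c(C)nc3c(N4CC[C@@H](NC(=O)COc5ccccc5)C4)cc(C)nn23)cc1OC` gives > 95%, also a limit. Compound 3 `COc1ccc(-c2c(C)nc3c(N4CC[C@@H](NC(=O)OC5CCCCC5)C4)cc(C)nn23)cc1OC` gives > 95%, again a limit. Compound 3 therefore has no exact position on the scale, and the other two values offer no number to rank it against. The record so far amounts to the limit of > 95% in this assay, at which 3 of the 3 values shown sit.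

Compound 4 `COc1ccc(-c2c(C)nc3c(N4CC[C@@H](NS(=O)(=O)C5CC5)C4)cc(C)nn23)cc1OC` has not yet been measured. It carries cyclopropylsulfonyl in place of cyclohexyloxycarbonyl on an amine nitrogen.

Among the measured compounds shown here, three measured steps bear on this change, each a swap of the group on a carbonyl carbon. They are a step that the two limits leave unreadable from compound 1 to compound 2, a step that the two limits leave unreadable from compound 1 to compound 3 and a step that the two limits leave unreadable from compound 2 to compound 3. None of them brings in cyclopropylsulfonyl, and none has a size that can be carried over. All that can be drawn from them is that three different groups left the read-out at the same limit, as the limit of > 95% in this assay, at which 3 of the 3 values shown sit, shows. No step beyond the usual scatter is therefore expected in this assay, although a modest fall would not be a surprise with a group not yet tested. The expected change is a step that the limit leaves unreadable from compound 3 to compound 4. The estimate for compound 4 is 96%, with an expected range from 82% to 100%.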

Compound 4, percent of the compound remaining: > 95%
Compound 4: no number, only a limit; the forecaster's own chance of this, stated with the estimate: 60%; the middle value is on the limit's open side.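

In this assay compound 4 gives > 95%, which is a limit of the assay and not a number. Among the compounds shown here, no step between compound 4 and compound 1, compound 2 or compound 3 can be read, and the record stays as it was: the limit of > 95% in this assay, at which 4 of the 4 values shown sit. The compounds shown leave open how far apart these four truly stand in stability.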